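The source may report more compounds than this note shows. Statements on the series, on what has been measured and on what is new or still open speak of the compounds shown alone.

In an ADME assay on HEK293 cells (Homo sapiens) for cytotoxicity, read by resazurin assay, with a stated time of 48 h (a lower number here means that less compound is tolerated, a higher number that more compound is tolerated), compound 1 (`COc1ccc(S(=O)(=O)Nc2ccc3oc(-c4ccc(NC(=O)c5cccc(C)c5[N+](=O)[O-])cc4)nc3c2)cc1`) gives 12000 nM and compound 2 (`O=S(=O)(Nc1ccc(-c2nc3cc(NS(=O)(=O)c4ccc(Br)cc4)ccc3o2)cc1)c1ccc(Br)cc1`) gives 22000 nM. These two numbers lie within the scatter of each other, so compound 1 holds no distinct place on this short scale. Within the data shown here, no measured pair differs in only one place, so no single change can yet be sized directly.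

Compound 3 (`COc1ccc(S(=O)(=O)Nc2ccc3oc(-c4ccc(NC(=O)C5CCN(C(C)=O)CC5)cc4)nc3c2)cc1`) keeps the rest of compound 1 and changes one group on a carbonyl carbon whose other neighbour is an amide-type nitrogen: 1-acetylpiperidin-4-yl takes the place of 3-methyl-2-nitrophenyl (1-acetylpiperidin-4-yl in place of 3-methyl-2-nitrophenyl on a carbonyl carbon). Among the measured compounds shown here, the only guide is the pair of measured values: compound 2, at 22000 nM, stays within the scatter of compound 1 at 12000 nM, although the two carry different groups. On that limited basis, no shift beyond the scatter is expected in this assay. The expected step is a 1.5-fold higher number from compound 1 to compound 3 (0.18 log units; within the scatter), a small upward estimate that remains within the scatter. In this assay, compound 3 is estimated at 18000 nM, with an expected range of 7000 nM to 45000 nM.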

Compound 3, half-maximal cytotoxic concentration: 34000 nM
The estimate for compound 3 lay 1.9-fold (0.28 log units) below the measured number, and the stated range covers the measured number.
By their numbers in this assay, from the lowest: compounds 1, 2 and 3 (each within the scatter of the next, the first and the last beyond it).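

In this assay, among these compounds, putting 1-acetylpiperidin-4-yl in place of 3-methyl-2-nitrophenyl on a carbonyl carbon gives a 2.8-fold higher number from compound 1 to compound 3 (0.45 log units; beyond the scatter), the first single change whose size can be read directly. With the rest of compound 1 held constant, the group on this carbonyl carbon is therefore enough to move the number beyond the scatter, although the step is modest and rests on one pair. The exchange replaces a six-membered aromatic ring of carbon only with a six-membered non-aromatic ring with one hetero atom and also changes the substituents on that ring, and no measurement shown accounts for the step.

Which part of the exchange carries the step remains open: an unsubstituted phenyl or a piperidine ring with a free amine in place of the acetyl, on the same carbonyl carbon, would begin to separate ring type from substituents. On these data alone, whether the step keeps its size when the sulfonamide end of compound 1 carries another group, such as a bromine in place of the methoxy, is also open.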